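Trifluoromethylphenyl Placement Across Two Hydroxyphenyl Cores

This account rests on a few compounds, and the source may have more. Where it says the series, first, only, none or still open, it means among the compounds named here.

Compound 1 `Oc1cccc(-c2cc(-c3cccc(C(F)(F)F)c3)cc(-c3ccccc3O)n2)c1` and compound 2 `Oc1cccc(-c2cc(-c3ccc(C(F)(F)F)cc3)cc(-c3ccccc3O)n2)c1` share one core; compound 3 `Oc1ccc(-c2cc(-c3cccc(C(F)(F)F)c3)cc(-c3ccc(O)cc3)n2)cc1` and compound 4 `Oc1ccc(-c2cc(-c3ccc(C(F)(F)F)cc3)cc(-c3ccc(O)cc3)n2)cc1` share another, and the difference between the two cores is not broken down here. In a functional assay on HeLa cells (Homo sapiens) for inhibition (a higher number here means a weaker inhibitor, a lower number a stronger inhibitor), compound 1 gives 19500 nM. Compound 2 reaches only the limit of > 50000 nM in this assay, so this is a limit and not a number. Compound 3 likewise reaches only the limit of > 50000 nM in this assay. The change 4-(trifluoromethyl)phenyl in place of 3-(trifluoromethyl)phenyl on an aromatic carbon gave an at least 2.5-fold higher number from compound 1 to compound 2 (0.40 log units; beyond the scatter). The change 4-(trifluoromethyl)phenyl in place of 3-(trifluoromethyl)phenyl on an aromatic carbon is the same kind of change, but its place is meta to two 4-hydroxyphenyl groups, where in the first pair it was meta to a 2-hydroxyphenyl group and meta to a 3-hydroxyphenyl group. Compound 4 is expected to stay at the limit as well, because of the limit of > 50000 nM in this assay, at which 2 of the 3 values shown sit, and because the step of an at least 2.5-fold higher number from compound 1 to compound 2 (0.40 log units; beyond the scatter) went upward from a measured number. The step expected is a step that the limit leaves unreadable from compound 3 to compound 4. The estimate for compound 4 in this assay is 90000 nM, with a range from 35000 nM to 300000 nM.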

Compound 4, half-maximal inhibitory concentration: > 50000 nM
Compound 4: no number, only a limit; the forecaster's own chance of this, stated with the estimate: 90%; the middle value does not contradict the limit.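

In this assay, compound 3 and compound 4 both give only a limit and not a number, so no new step can be read between them. The compounds shown leave open whether 4-(trifluoromethyl)phenyl in place of 3-(trifluoromethyl)phenyl changes inhibition at all on the core shared by compound 3 and compound 4.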